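Replacing the aryl group of compound 1 with a methyl group

The compounds below may be only part of what the source reports. "The series", "measured", "known", "first", "only" and "open" are said of these compounds alone.

Measured so far in a functional assay on A549 cells (Homo sapiens) for inhibition, read by MTT assay, with a stated time of 72 h; on this read-out lower numbers stand for stronger inhibition and higher numbers for weaker inhibition:
- compound 1, `CC(C)(C)n1cc2c(n1)C(=O)CC1(CCN(C(=O)c3cc(-c4ccc(F)cc4)nc4ccccc34)CC1)O2`: 5770 nM
- compound 2, `CC(C)(C)n1cc2c(n1)C(=O)CC1(CCN(C(=O)c3cc(-c4ccc(N)cc4)nc4ccccc34)CC1)O2`: 970 nM
- compound 3, `CC(C)(C)n1cc2c(n1)C(=O)CC1(CCN(C(=O)c3cc(-c4ccccn4)nc4ccccc34)CC1)O2`: 7720 nM

Compound 1 stands second highest of the three numbers in this assay. Its nearest neighbour is compound 3, reached by a 1.3-fold higher number from compound 1 to compound 3 (0.13 log units; within the scatter); its furthest is compound 2, reached by a 5.9-fold lower number from compound 1 to compound 2 (0.77 log units; beyond the scatter). The remaining pair gives an 8.0-fold higher number from compound 2 to compound 3 (0.90 log units; beyond the scatter).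

Compound 4, `Cc1cc(C(=O)N2CCC3(CC2)CC(=O)c2nn(C(C)(C)C)cc2O3)c2ccccc2n1`, is not yet measured. Compared with compound 1 it differs in one place: methyl in place of 4-fluorophenyl on an aromatic carbon. The new group sits on an aromatic carbon of a six-membered aromatic ring with one nitrogen, within a fused system of two rings.

Among the compounds with values here, none of the measured steps bears directly on this change. Both steps from compound 1 swap one six-membered aromatic ring for another, and they show that changing the substituent on that ring can shift the number modestly, as a 5.9-fold lower number from compound 1 to compound 2 (0.77 log units; beyond the scatter) did, or hardly at all, as a 1.3-fold higher number from compound 1 to compound 3 (0.13 log units; within the scatter) did. Removing the whole ring is a larger change than either. The expectation is therefore a step upward in this assay, a 2.4-fold higher number from compound 1 to compound 4 (0.38 log units; beyond the scatter), though the three compounds give no firm guide to its size. Compound 4 is estimated at 14000 nM, with a range from 4500 nM to 45000 nM.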

Compound 4, half-maximal inhibitory concentration: > 10000 nM
Compound 4: no number, only a limit; the forecaster's own chance of this, stated with the estimate: 20%; the middle value is on the limit's open side.
By their numbers in this assay, from the lowest: compound 2; then compounds 1 and 3 (each within the scatter of the next). At a limit, above all of these: compound 4.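

In this assay compound 4 gives > 10000 nM, which is a limit of the assay and not a number. With methyl on this carbon next to the ring nitrogen, the clearest result is an at least 10-fold higher number from compound 2 to compound 4 (1.01 log units; beyond the scatter), so compound 2, with its 4-aminophenyl group, keeps the lowest number of the four compounds. The other two steps, an at least 1.7-fold higher number from compound 1 to compound 4 (0.23 log units; that floor lies within the scatter) and an at least 1.2-fold higher number from compound 3 to compound 4 (0.11 log units; that floor lies within the scatter), have floors within the scatter, so they cannot separate compound 4 from either compound, but the limit gives no sign that a small methyl group can replace the aromatic ring with any gain at this position.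

From the compounds shown here alone, how far compound 4 lies beyond its limit remains unknown. Also open, going by these compounds, is whether an amine placed directly on this carbon, or a 4-hydroxyphenyl group, would match compound 2.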